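The compounds below may be only part of what the source reports. "The series", "measured", "known", "first", "only" and "open" are said of these compounds alone.

Measured so far:
- compound 1, `O=C(Nc1ccccn1)c1c(O)c2cccnc2n(-c2ccccc2)c1=O`: -13.5%
- compound 2, `CN(C)CCNC(=O)c1c(O)c2cccnc2n(-c2ccccc2)c1=O`: 22.6%
- compound 3, `Nc1ccc(NC(=O)c2c(O)c3cccnc3n(-c3ccccc3)c2=O)cc1`: -5.5%

In a functional assay on the whole organism for inhibition, with Rattus norvegicus as the target, read by paw edema, at a dose of 100 mg/kg by the oral route (on this read-out higher numbers stand for more inhibition at the one dose given (going by the name of the read-out) and lower numbers for less inhibition), compound 2 has the highest number of the three, beyond the scatter from both others. Compound 4, `O=C(Nc1cccnc1)c1c(O)c2cccnc2n(-c2ccccc2)c1=O`, differs from compound 2 by pyridin-3-yl in place of 2-(dimethylamino)ethyl on an amide-type nitrogen. Among the compounds with values here, two measured steps bear on this: a number 36.1 percentage points higher from compound 1 to compound 2 (beyond the scatter) and a number 28.1 percentage points lower from compound 2 to compound 3 (beyond the scatter), both showing that a ring on the amide-type nitrogen in place of the 2-(dimethylamino)ethyl chain, or the reverse, moves this assay by a large or modest amount. Compound 4 carries a ring again, so a fall beyond the scatter is expected, with a number 30.6 percentage points lower from compound 2 to compound 4 (beyond the scatter). Compound 4 is therefore estimated at -8%, between -25% and 10%.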

Compound 4, a percentage reported as inhibition, in the whole organism at one dose (the size of the read-out at that dose, not a potency): 30.3%
For compound 4 the middle estimate is 38.3 percentage points below the measured one; the whole stated range lies below it.
By their numbers in this assay, from the lowest: compounds 1 and 3 (each within the scatter of the next); then compounds 2 and 4 (each within the scatter of the next).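

A ring on the amide-type nitrogen does not by itself lose the effect in this assay: the step to pyridin-3-yl is a number 7.7 percentage points higher from compound 2 to compound 4 (within the scatter), so this ring and the 2-(dimethylamino)ethyl chain cannot be told apart here. Which ring it is matters far more, with a number 43.8 percentage points higher from compound 1 to compound 4 (beyond the scatter) for the swap from pyridin-2-yl and a number 35.8 percentage points higher from compound 3 to compound 4 (beyond the scatter) for the swap from 4-aminophenyl. Nothing available explains these differences.

Still open, going by these compounds, is how pyridin-4-yl on the same nitrogen would read, and whether a longer chain such as 3-(dimethylamino)propyl would hold this level.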